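Branching the Nitrogen Substituent in a Bile Acid Receptor Series

The compounds below may be only part of what the source reports. "The series", "measured", "known", "first", "only" and "open" are said of these compounds alone.

Three compounds have been measured in an assay on isolated protein for agonist activity at Bile acid receptor (Homo sapiens), read by TR-FRET; a lower number here means that less compound is needed, a higher number that more compound is needed for the effect:

compound 1, `CCC(CC)n1c(-c2ccc(OCc3c(-c4c(Cl)cccc4Cl)noc3C(C)C)cc2F)nc2ccc(C(=O)O)cc21`, gives 69.3 nM
compound 2, `CCCn1c(-c2ccc(OCc3c(-c4c(Cl)cccc4Cl)noc3C(C)C)cc2)nc2ccc(C(=O)O)cc21`, gives 96.4 nM
compound 3, `CC(C)c1onc(-c2c(Cl)cccc2Cl)c1COc1ccc(-c2nc3ccc(C(=O)O)cc3n2CC2CCCCC2)c(Cl)c1`, gives 66.1 nM

Compound 2 carries the highest of the three numbers in this assay, but its distance to compound 1 and to compound 3 lies within the usual scatter of the measurement, so the three values cannot be ranked against each other; they read as one level of activity reached with three different groups on the ring nitrogen of the shared core.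

Compound 4, `CC(C)c1onc(-c2c(Cl)cccc2Cl)c1COc1ccc(-c2nc3ccc(C(=O)O)cc3n2C(C)C)cc1`, is compound 2 rebuilt from the same atoms: isopropyl in place of propyl on an aromatic nitrogen. Among the compounds with values here, no pair of measured compounds isolates this change, so nothing measured tells how the shared core answers to branching of a three-carbon chain at that position. Given that a propyl, a pentan-3-yl and a cyclohexylmethyl group all sit at the same level, the expectation is a step of no size beyond the scatter, in no preferred direction. The expected step is a 1.1-fold lower number from compound 2 to compound 4 (0.03 log units; within the scatter). Compound 4 is thus estimated at 90 nM in this assay, with a range from 35 nM to 250 nM.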

Compound 4, half-maximal effective concentration: 56.7 nM
Estimate against measurement, compound 4: 1.6-fold (0.20 log units) above; measured number inside the range.
By their numbers in this assay, from the lowest: compounds 4, 3, 1 and 2 (each within the scatter of the next).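

Within the data shown here, with compound 4, a single change on the aromatic nitrogen can be read for the first time: in this assay, isopropyl in place of propyl gives a 1.7-fold lower number from compound 2 to compound 4 (0.23 log units; within the scatter) at this position. The two groups have the same count of carbon atoms and differ only in how those atoms are joined, so this pair shows that the shared core holds its level of activity when the three-carbon chain is branched, with no difference that can be told apart from the scatter. This is a direct result for one pair; the values of compound 1 and compound 3 could only suggest it, since each of those compounds differs from compound 2 in more than one place, and nothing among the data shown accounts for the step.

What the compounds shown leave open is how far this tolerance reaches at the aromatic nitrogen, whether with a smaller group such as methyl, a more heavily branched one such as tert-butyl, or a compact ring such as cyclopropyl. As far as these compounds go, it is also open whether a chain ending in an amine or a hydroxyl group would hold the same level in this assay.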